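Diamino quinoxaline series: aryl-sulfanyl variation at the para position

The source may report more compounds than this note shows. Statements on the series, on what has been measured and on what is new or still open speak of the compounds shown alone.

Measured compounds:
- compound 1, `Nc1cc(N)c2nc(-c3ccccc3)c(NCc3ccc(Cl)c(Cl)c3)nc2c1`, 40700 nM
- compound 2, `Nc1cc(N)c2nc(-c3ccccc3)c(Sc3ccc(F)cc3)nc2c1`, 45700 nM
- compound 3, `COc1cc(CNc2nc3cc(N)cc(N)c3nc2-c2ccccc2)cc(OC)c1OC`, a limit only

In a functional assay on OVCAR-5 cells (Homo sapiens) for inhibition, read by sulforhodamine B assay, with a stated time of 48 h (on this read-out lower numbers stand for stronger inhibition of growth and higher numbers for weaker inhibition of growth), compound 1 gives 40700 nM and compound 2 gives 45700 nM; the two numbers sit within the usual scatter of each other, so no order between them can be read. For compound 3 the result is a limit of the assay and not a number, < 50200 nM; one of the three values shown sits at that limit (the limit of < 50200 nM in this assay, at which 1 of the 3 values shown sits). Among the two numbers, compound 2 holds the higher figure, though only by a margin inside the scatter.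

Compound 4, `COc1ccc(Sc2nc3cc(N)cc(N)c3nc2-c2ccccc2)cc1`, has not been measured in this assay. It differs from compound 2 at one place: methoxy in place of fluoro on an aromatic carbon. For the measured compounds named here, no step between measured compounds bears on this change, so the expected step in this assay is none beyond the scatter, with the weak pull of a limit nearby. Compound 4 is therefore estimated at 45000 nM, range 20000 nM to 100000 nM, which means an expected step of a 1.0-fold lower number from compound 2 to compound 4 (0.01 log units; within the scatter) from compound 2.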

Compound 4, concentration for total growth inhibition: < 100000 nM
Compound 4 ended at the assay's limit; the forecaster's own chance of this, stated with the estimate: 30%; the middle value does not contradict the limit.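

In this assay, for the compounds shown here, compound 4 gives a limit of the assay and not a number, < 100000 nM, so no step from compound 2 to compound 4 can be read. The compounds shown leave open whether methoxy in place of fluoro on an aromatic carbon changes growth inhibition at all.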